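A few compounds are considered here, and "the series" means these few. Any claim that something is new, unique, unknown or untested is made for them only; others in the source may bear on it.

Compound 1 `COc1ccc(C(=O)N(CCC(=O)NCc2ccccc2)Cc2ccc(C(=O)NO)cc2)cc1` carries a methoxy on the aromatic ring of its benzoyl arm. In a functional assay on CHP-134 cells (Homo sapiens) for antiproliferative activity, with a stated time of 72 h (on this read-out lower numbers stand for stronger inhibition and higher numbers for weaker inhibition), compound 1 gives 1900 nM, which places it second highest among the three measured compounds. Within the data shown here, compound 3 `O=C(CCN(Cc1ccc(C(=O)NO)cc1)C(=O)c1ccccc1)NCc1ccccc1` gives 4680 nM in this assay, and the only single-site step measured here, a 2.5-fold higher number from compound 1 to compound 3 (0.39 log units; beyond the scatter), shows that removing the methoxy weakens the effect. Among the measured compounds shown here, compound 2 `Cc1ccc(NC(=O)CCN(Cc2ccc(C(=O)NO)cc2)C(=O)c2ccc(N(C)C)cc2)cc1` gives 540 nM in this assay; it carries a dimethylamino group on the same ring as the methoxy of compound 1, but it also differs in its amide arm, so no single-site step links it to compound 1.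

Compound 4 `CN(C)c1ccc(C(=O)N(CCC(=O)NCc2ccccc2)Cc2ccc(C(=O)NO)cc2)cc1` differs from compound 1 by dimethylamino in place of methoxy on an aromatic carbon. Because the step of a 2.5-fold higher number from compound 1 to compound 3 (0.39 log units; beyond the scatter) shows this ring position matters, and because compound 2 with a dimethylamino group gives 540 nM, a lower number is expected for compound 4. The step from compound 1 to compound 4 is estimated at a 2.1-fold lower number from compound 1 to compound 4 (0.32 log units; beyond the scatter). Compound 4 is expected to give about 900 nM, within a range from 400 nM to 2000 nM.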

Compound 4, half-maximal inhibitory concentration: 1160 nM
Compound 4: the middle estimate sits 1.3-fold (0.11 log units) below what was measured; the measured number falls inside the stated range.
By their numbers in this assay, from the lowest: compound 2; then compounds 4 and 1 (each within the scatter of the next); then compound 3.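

Putting dimethylamino in place of methoxy on this aromatic carbon gives a 1.6-fold lower number from compound 1 to compound 4 (0.21 log units; within the scatter), so the two groups cannot be told apart here. Dimethylamino in place of hydrogen gives a 4.0-fold lower number from compound 3 to compound 4 (0.61 log units; beyond the scatter), which means that compound 3, with neither group, has a higher number than compound 1 and compound 4, each of which carries one. Compound 2 and compound 4 both carry dimethylamino, and benzyl in place of 4-methylphenyl on the amide-type nitrogen gives a 2.1-fold higher number from compound 2 to compound 4 (0.33 log units; beyond the scatter), so the low number of compound 2 goes with its amide arm and shows that this second site also matters.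

The data shown offer no explanation for these steps. Going by these compounds, how a fluorine atom or a carboxylic acid at the same place would compare with methoxy and dimethylamino stays open.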